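Benzylidene piperidine amides: variation at the acid end

The source may hold more compounds than are shown below. What is called first, only, known or untested is meant among the compounds shown, and "the series" means these compounds.

In an assay on isolated protein for inhibition of 3-oxo-5-alpha-steroid 4-dehydrogenase 2 (Homo sapiens) (on this read-out lower numbers stand for stronger inhibition and higher numbers for weaker inhibition), compound 1 `O=C(O)c1ccc(C=C2CCN(C(=O)C(C3CCCCC3)C3CCCCC3)CC2)cc1` gives 60 nM. Compound 2 `O=C(O)c1ccc(C=C2CCN(C(=O)CC(c3ccccc3)c3ccccc3)CC2)cc1` gives 1100 nM in this assay, so compound 1 stands with the lowest of the two numbers, and its gap to compound 2 lies beyond the scatter. Compound 3 `O=C(O)Cc1ccc(C=C2CCN(C(=O)C(C3CCCCC3)C3CCCCC3)CC2)c(F)c1` follows from compound 1 by 4-(carboxymethyl)-2-fluorophenyl in place of 4-carboxyphenyl on a double-bonded chain carbon bound to a double-bonded ring carbon, while the amide side of the shared core is kept unchanged. Among the measured compounds shown here, no measured pair in this set shows a change of this kind: the two known compounds differ from each other only on the amide side, and nothing among them speaks to the acid end. The step of a 1.3-fold higher number from compound 1 to compound 3 (0.12 log units; within the scatter) is therefore expected to be small, of no settled direction, and quite possibly within the scatter. Compound 3 is estimated at 80 nM in this assay, within a range from 20 nM to 300 nM.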

Compound 3, half-maximal inhibitory concentration: 7 nM
Compound 3: the middle estimate sits 11-fold (1.06 log units) above what was measured, and the stated range ends above it.
By their numbers in this assay, from the lowest: compound 3; then compound 1; then compound 2.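

The acid end, on which the earlier pair was silent, is not a neutral position: in this assay the replacement of 4-carboxyphenyl by 4-(carboxymethyl)-2-fluorophenyl gives an 8.6-fold lower number from compound 1 to compound 3 (0.93 log units; beyond the scatter), with the amide side unchanged. A carboxymethyl group and a fluorine are therefore accepted together at this place on the shared core, and the number falls beyond the scatter. No measurement here speaks to what lies behind this fall.

As far as these compounds go, the step carries two changes at once, so the shares of the carboxymethyl group and the fluorine stay open; a 4-(carboxymethyl)phenyl group and a 4-carboxy-2-fluorophenyl group would separate them. Also open, from the compounds shown here alone, are a longer chain ending in the carboxylic acid, a tetrazole in place of that acid, and whether the step holds with the amide side of compound 2.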